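The source may hold more compounds than are shown below. What is called first, only, known or untested is meant among the compounds shown, and "the series" means these compounds.

In an ADME assay on CHO-K1 cells (Cricetulus griseus) for cytotoxicity, read by MTT assay, with a stated time of 24 h (on this read-out higher numbers stand for lower toxicity in this test and lower numbers for higher toxicity in this test), compound 2 `OCc1ccc(NC(=S)Nc2ccc3[nH]ccc3c2)cc1` gives 1080000 nM and compound 1 `Oc1ccc(NC(=S)Nc2ccc3[nH]ccc3c2)cc1` gives 848000 nM, so the two values lie within the scatter of each other. Compound 3 `COc1ccc(NC(=S)Nc2ccc3[nH]ccc3c2)cc1` has methoxy in place of hydroxymethyl on an aromatic carbon, para to a large group: methoxy in place of hydroxymethyl on an aromatic carbon. Within the data shown here, the only measured step at this place, a 1.3-fold higher number from compound 1 to compound 2 (0.11 log units; within the scatter), stays within the scatter, so no change beyond the scatter is expected in this assay. The expected step is a 1.2-fold lower number from compound 2 to compound 3 (0.08 log units; within the scatter). For compound 3 the estimated value is 900000 nM, with an expected range of 400000 nM to 2000000 nM.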

Compound 3, concentration lethal to 50% of the cells: 476000 nM
Compound 3: middle estimate off by 1.9-fold (0.28 log units), on the high side; the range from low to high includes it.
By their numbers in this assay, from the lowest: compounds 3, 1 and 2 (each within the scatter of the next, the first and the last beyond it).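

In this assay, among these compounds, methoxy in place of hydroxymethyl, on an aromatic carbon para to a large group, gives a 2.3-fold lower number from compound 2 to compound 3 (0.36 log units; beyond the scatter) as the first step at this place to pass the scatter, a modest one, between two groups with the same heavy atoms. Methyl in place of hydrogen on the oxygen gives a 1.8-fold lower number from compound 1 to compound 3 (0.25 log units; within the scatter) and stays within the scatter, so only hydroxymethyl and methoxy are separated here. No evidence at hand bears on this step. From the compounds shown here alone, whether an amine, a carboxylic acid or a longer chain such as ethoxy at this place would shift the number in this assay stays open.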